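The source may hold more compounds than are shown below. What is called first, only, known or untested is meant among the compounds shown, and "the series" means these compounds.

Compound 1 `COc1ccc(-c2cccc(C(=O)N(C)C)c2)cc1S(=O)(=O)Nc1ccc2ccc(NC(=O)c3ccccc3)cc2c1`: in a functional assay on CHO cells for agonist activity at Orexin/Hypocretin receptor type 1 (Homo sapiens) (a higher number here means that more compound is needed for the effect, a lower number that less compound is needed), compound 1 gives > 10000 nM, which is a limit of the assay.
Compound 2 `COc1ccc(-c2cccc(C(=O)N(C)C)c2)cc1S(=O)(=O)Nc1ccc2ccc(N(C)C(=O)c3ccccc3)cc2c1`: in this assay compound 2 gives > 10000 nM, again a limit of the assay.
Compound 3 `COc1cccc(C(=O)Nc2c(C)ccc3ccc(NS(=O)(=O)c4cc(-c5cccc(C(=O)N(C)C)c5)ccc4OC)cc23)c1`: in this assay compound 3 gives 148 nM.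

Compound 3 is the only one of the three with a number; the other two values sit at the limit of > 10000 nM in this assay, at which 2 of the 3 values shown sit. Compound 1 and compound 2 differ by methyl in place of hydrogen on an amide-type nitrogen, and the step that the two limits leave unreadable from compound 1 to compound 2 cannot be read from two limits. How the core of compound 3 differs from the core of compound 1 is not broken down here. Compound 4 `COc1cccc(C(=O)N(C)c2c(C)ccc3ccc(NS(=O)(=O)c4cc(-c5cccc(C(=O)N(C)C)c5)ccc4OC)cc23)c1` has not been measured; it differs from compound 3 by methyl in place of hydrogen on an amide-type nitrogen, the same change made from compound 1 to compound 2, at the same kind of place. With the earlier step unreadable, the expectation rests on compound 3 with 148 nM as the starting point and wide uncertainty. Compound 4 is expected to show a step of a 3.0-fold higher number from compound 3 to compound 4 (0.48 log units; beyond the scatter). Compound 4 is estimated at 450 nM, with an expected range from 100 nM to 4000 nM.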

Compound 4, half-maximal effective concentration: 260 nM
Compound 4: the middle estimate sits 1.7-fold (0.24 log units) above what was measured; the range from low to high includes it.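

On the core of compound 3, methyl in place of hydrogen on the amide-type nitrogen gives a 1.8-fold higher number from compound 3 to compound 4 (0.24 log units; within the scatter) in this assay, so on this core the change leaves no difference beyond the scatter. The same change on the core of compound 1 cannot be read, because compound 1 and compound 2 both stand at a limit of the assay: the limit of > 10000 nM in this assay, at which 2 of the 4 values shown sit.

This leaves one readable instance of the change, so whether its outcome carries from one core to another is not shown. The compounds shown leave open how this assay reads with ethyl or a longer chain in place of the methyl on this nitrogen. They also leave open what an amine or a carboxylic acid at the end of such a chain would give.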